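Fluoro for Hydrogen on the Unsubstituted Ring

The source may hold more compounds than are shown below. What is called first, only, known or untested is meant among the compounds shown, and "the series" means these compounds.

Measured so far:
compound 1 `COc1cc(OC)c(C(=O)/C=C/c2ccccc2SC)c(OC)c1` — 24%
compound 2 `COc1cccc(/C=C/C(=O)c2c(OC)cc(OC)cc2OC)c1` — 19%
compound 3 `COc1cc(OC)c(C(=O)/C=C/c2ccccc2)c(OC)c1` — 18%

Of the compounds shown here, three sharing one core have been tested in a functional assay on HaCaT cells (Homo sapiens), read by fluorescence and BrdU incorporation, with a stated time of 48 h, tested at 10 uM; on this read-out higher numbers stand for a weaker effect at the one concentration tested and lower numbers for a stronger effect. Compound 1 `COc1cc(OC)c(C(=O)/C=C/c2ccccc2SC)c(OC)c1` gives 24%, compound 2 `COc1cccc(/C=C/C(=O)c2c(OC)cc(OC)cc2OC)c1` gives 19%, and compound 3 `COc1cc(OC)c(C(=O)/C=C/c2ccccc2)c(OC)c1` gives 18%. Compound 3 carries the lowest of the three numbers, its nearest neighbour being compound 2 and its furthest compound 1, yet both gaps lie within the scatter, so nothing separates the three. The single-change steps agree: a number 5 percentage points lower from compound 1 to compound 2 (within the scatter), a number 6 percentage points lower from compound 1 to compound 3 (within the scatter) and a number 1 percentage points lower from compound 2 to compound 3 (within the scatter).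

Compound 4 `COc1cc(OC)c(C(=O)/C=C/c2ccc(F)cc2)c(OC)c1` has not been measured. It differs from compound 3 by fluoro in place of hydrogen on an aromatic carbon. Going by the values given here, no measured pair shows this exact change. The closest guides are the two steps into compound 3, in which a methylsulfanyl or a methoxy group leaves an aromatic carbon of that ring, a number 6 percentage points lower from compound 1 to compound 3 (within the scatter) and a number 1 percentage points lower from compound 2 to compound 3 (within the scatter), neither beyond the scatter. Changes on that ring have so far moved this assay little across compounds 1, 2 and 3. Compound 4 is therefore expected to sit close to that level, with no change at the digits printed from compound 3 to compound 4 (within the scatter) expected to remain within the scatter. Compound 4 is estimated at 18%, with a range from 8% to 30%.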

Compound 4, a percentage reported as activity, at one concentration (the size of the read-out at that concentration, not a potency): 20%
Beside the measured number, compound 4's estimate is 2 percentage points below it; the measured number falls inside the stated range.
By their numbers in this assay, from the lowest: compounds 3, 2, 4 and 1 (each within the scatter of the next).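

Fluoro in place of hydrogen, on an aromatic carbon para to a large group, puts a substituent at a place on this ring that none of the earlier compounds occupied, and in this assay it gives a number 2 percentage points higher from compound 3 to compound 4 (within the scatter). Compound 4 also stays level with the two compounds substituted elsewhere on that ring, with a number 1 percentage points higher from compound 2 to compound 4 (within the scatter) and a number 4 percentage points lower from compound 1 to compound 4 (within the scatter), so this third placement, with a different group, extends the flat picture that compounds 1, 2 and 3 had shown only for methylsulfanyl and methoxy. No measurement is at hand that could explain this result or link it to any property of the fluoro group.

The compounds shown leave open whether any other group at this same place, such as a carboxylic acid, a dimethylamino group or a butoxy chain, would move the number beyond the scatter, or whether this ring tolerates nearly anything. They also leave open whether compounds that read alike at the single concentration of this assay would still differ in potency once tested across a range of concentrations.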